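The source may report more compounds than this note shows. Statements on the series, on what has been measured and on what is new or still open speak of the compounds shown alone.

Measured so far in a functional assay on A549 cells (Homo sapiens) for cytotoxicity, read by MTT assay, with a stated time of 72 h; on this read-out lower numbers stand for an effect already at smaller amounts and higher numbers for an effect only at larger amounts of compound:
compound 1 `CCc1cccc2c(OC)c(-c3occ(C)c3C(=O)OC)ccc12` – 1.5 ug/mL
compound 2 `CCOC(=O)c1c(C)coc1-c1ccc2c(CC)cccc2c1OC` – 3.8 ug/mL
compound 3 `CCOc1c(-c2occ(C)c2C(=O)OC)ccc2c(CC)cccc12` – 2.4 ug/mL

Three close relatives of one core have been tested. Compound 3 holds the second highest of the three numbers; its gap to compound 1 and its gap to compound 2 both stay within the usual scatter, so no order among the three can be read from these values. Two single-point changes have been measured: a 2.5-fold higher number from compound 1 to compound 2 (0.40 log units; beyond the scatter), and a 1.6-fold higher number from compound 1 to compound 3 (0.20 log units; within the scatter).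

Compound 4 `CCOc1c(-c2occ(C)c2COC(C)=O)ccc2c(CC)cccc12` differs from compound 3 in one place: acetoxymethyl in place of methoxycarbonyl on an aromatic carbon. Within the data shown here, of the two measured steps, only the one from compound 1 to compound 2 touches the same region, the ester on the five-membered ring, and there a small enlargement already gave a modest rise in the number. The change to compound 4 is larger than that one, so a small rise in this assay, or no change beyond the scatter, is the plausible outcome; the data do not show a change of this exact kind.

Compound 4 is therefore expected to give about 4 ug/mL in this assay, most likely between 1.5 ug/mL and 11 ug/mL, which would mean an estimated step of a 1.7-fold higher number from compound 3 to compound 4 (0.22 log units; within the scatter).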

Compound 4, concentration for half-maximal effect: > 10 ug/mL
Compound 4 was reported as a limit (the forecaster's own chance of this, stated with the estimate: 5%); middle value at least 2.5-fold (0.39 log units) away from the limit.
By their numbers in this assay, from the lowest: compounds 1, 3 and 2 (each within the scatter of the next, the first and the last beyond it). At a limit, above all of these: compound 4.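

In this assay, compound 4 gives > 10 ug/mL, which is a limit of the assay and not a number. Exchanging methoxycarbonyl for acetoxymethyl on this aromatic carbon of the five-membered ring gives an at least 4.1-fold higher number from compound 3 to compound 4 (0.61 log units; beyond the scatter), so the effect on these cells now appears only at clearly larger amounts, even though the two groups have the same counts of hydrogen-bond donors and acceptors and neither carries a net charge. The earlier step at this site, a 2.5-fold higher number from compound 1 to compound 2 (0.40 log units; beyond the scatter), changed only the far end of the ester, whereas this one changes how the group is built and shows that this position tolerates such a change poorly, with the true size of the step still unknown, as only a lower bound can be given: the limit of > 10 ug/mL in this assay, at which 1 of the 4 values shown sits.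

The compounds shown leave open whether a carboxylic acid, a hydroxymethyl or an amide on this carbon would keep the number close to that of compound 3 at 2.4 ug/mL. They also leave open whether the same exchange would act alike on compound 1, which gives 1.5 ug/mL.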